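This account rests on a few compounds, and the source may have more. Where it says the series, first, only, none or still open, it means among the compounds named here.

Measured so far in an assay on RBL-1 cells for inhibition of Polyunsaturated fatty acid 5-lipoxygenase (Rattus norvegicus); a higher number here means a weaker inhibitor, a lower number a stronger inhibitor: compound 1 `O=C1NCCN(c2cccc(F)c2)N1` gives 19000 nM; compound 2 `O=C1NCCN(c2cccc(Cl)c2)N1` gives 5300 nM; compound 3 `CSc1cccc(N2CCNC(=O)N2)c1` gives 14000 nM.

Compound 3 stands second highest of the three numbers: a 2.6-fold higher number from compound 2 to compound 3 (0.42 log units; beyond the scatter) sets it apart from compound 2, whereas a 1.4-fold lower number from compound 1 to compound 3 (0.13 log units; within the scatter) leaves it within the scatter of compound 1. The next step leads to compound 4 `O=C1NCCN(c2cccc(-c3ccccn3)c2)N1`: pyridin-2-yl in place of methylsulfanyl on an aromatic carbon. The measured steps that bear on the aromatic carbon concerned, a 1.4-fold lower number from compound 1 to compound 3 (0.13 log units; within the scatter) and a 2.6-fold higher number from compound 2 to compound 3 (0.42 log units; beyond the scatter), each swap one small group for another, and a 3.6-fold lower number from compound 1 to compound 2 (0.55 log units; beyond the scatter) is the largest change seen; none brings in a ring, so no direct guide exists. A step of modest size at most is expected in this assay, with no clear direction. Compound 4 is estimated at 10000 nM, range 2500 nM to 40000 nM. The expected step is therefore a 1.4-fold lower number from compound 3 to compound 4 (0.15 log units; within the scatter).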

Compound 4, half-maximal inhibitory concentration: 30000 nM
The estimate for compound 4 lay 3.0-fold (0.48 log units) below the measured number, within the range that was stated.
By their numbers in this assay, from the lowest: compound 2; then compounds 3, 1 and 4 (each within the scatter of the next, the first and the last beyond it).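

In this assay, going by these compounds alone, the first ring at this aromatic carbon, pyridin-2-yl, gives a 2.1-fold higher number from compound 3 to compound 4 (0.33 log units; beyond the scatter) and a 5.7-fold higher number from compound 2 to compound 4 (0.75 log units; beyond the scatter) as the largest step so far, while a 1.6-fold higher number from compound 1 to compound 4 (0.20 log units; within the scatter) leaves it level with the fluoro compound. Among the groups shown, the six-membered aromatic ring brings no gain over the small groups, and chloro remains the best at this position. No evidence is available to explain these steps.

Going by these compounds, whether a plain phenyl ring would behave like pyridin-2-yl remains open. So does whether bromo, trifluoromethyl, an aminomethyl group or a carboxylic acid could improve on chloro.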